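The compounds below may be only part of what the source reports. "The series", "measured", "known", "first", "only" and "open" are said of these compounds alone.

Measured compounds:
- Compound 1, `COc1ccc(C(=O)C2Sc3nnc(-c4cc(OC)c(OC)c(OC)c4)n3NC2c2cccs2)cc1`: in a functional assay on A549 cells (Homo sapiens) for cytotoxicity, read by MTT assay, with a stated time of 48 h (on this read-out higher numbers stand for weaker inhibition and lower numbers for stronger inhibition), compound 1 gives > 100000 nM, which is a limit of the assay and not a number.
- Compound 2, `COc1cc(-c2nnc3n2NC(c2ccco2)C(C(=O)c2cccs2)S3)cc(OC)c1OC`: in this assay compound 2 gives 78700 nM.
- Compound 3, `COc1cc(-c2nnc3n2NC(c2cccs2)C(C(=O)c2ccc(Cl)cc2)S3)cc(OC)c1OC`: in this assay compound 3 gives 20100 nM.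

For the measured compounds named here, of the two numbers read so far, compound 2 stands highest; compound 3 is nearest, with a lower number, and that gap lies beyond the scatter. Going by the values given here, the only single-point step measured is an at least 4.9-fold lower number from compound 1 to compound 3 (0.69 log units; beyond the scatter), and since compound 1 sits at the limit (the limit of > 100000 nM in this assay, at which 1 of the 3 values shown sits), only a lower bound on its size is known.

Compound 4, `COc1cc(-c2nnc3n2NC(c2ccco2)C(C(=O)c2cccc4ccccc24)S3)cc(OC)c1OC`, differs from compound 2 in one place: naphthalen-1-yl in place of thiophen-2-yl on a carbonyl carbon. Among the compounds with values here, no measured step touches the group on the carbonyl carbon; the step from compound 1 to compound 3 concerns a chloro in place of a methoxy on an aromatic carbon and does not bear on this change. With nothing in the series to anchor a direction, the step expected from compound 2 to compound 4 in this assay is a 1.3-fold lower number from compound 2 to compound 4 (0.12 log units; within the scatter), that is, none beyond the scatter. Compound 4 is accordingly estimated at 60000 nM, within a range of 20000 nM to 150000 nM, with a fair chance that only a limit is returned.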

Compound 4, half-maximal inhibitory concentration: > 100000 nM
Compound 4 gave a limit, no number; the forecaster's own chance of this, stated with the estimate: 25%; middle value at least 1.6-fold (0.22 log units) away from the limit.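

The first step measured at the group on the carbonyl carbon is an at least 1.2-fold higher number from compound 2 to compound 4 (0.10 log units; that floor lies within the scatter) in this assay, so the floor of this change does not clear the scatter. Compound 4 gives a limit of the assay and not a number, which leaves the true size of the step unknown, and it now shares that limit with compound 1: the limit of > 100000 nM in this assay, at which 2 of the 4 values shown sit.

Set against compound 2 at 78700 nM, the 10 heavy atoms of naphthalen-1-yl in place of the 5 of thiophen-2-yl bring no lower number, so this change on the carbonyl carbon gives no sign of a gain in the series.

From the compounds shown here alone, what remains open is how far upward the number moves with naphthalen-1-yl, and whether this place tolerates anything other than an aromatic ring, such as a plain methyl, a dimethylamino group or a carboxylic acid. Whether the outcome of this change carries over to the shared core with thiophen-2-yl in place of the furan ring of compound 2 also stays unanswered.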